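This account rests on a few compounds, and the source may have more. Where it says the series, first, only, none or still open, it means among the compounds named here.

Of the compounds shown here, three built on one shared core have been measured in a functional assay on SK-HEP1 cells (Homo sapiens) for cytotoxicity, read by sulforhodamine B assay, with a stated time of 72 h (a lower number here means a stronger inhibitor, a higher number a weaker inhibitor), and they differ only in the aryl group attached to a nitrogen on an aromatic ring. Compound 1 `CCS(=O)(=O)Nc1cc(-c2ccc3ncnc(Nc4cccc(F)c4)c3c2)cnc1OC` gives 1850 nM. Compound 2 `CCS(=O)(=O)Nc1cc(-c2ccc3ncnc(Nc4ccc(OC)c(Cl)c4)c3c2)cnc1OC` gives 2810 nM, and compound 3 `CCS(=O)(=O)Nc1cc(-c2ccc3ncnc(Nc4cccc(C(=O)OC)c4)c3c2)cnc1OC` gives 2400 nM. Compound 1 has the smallest number of the three, yet the steps of a 1.5-fold higher number from compound 1 to compound 2 (0.18 log units; within the scatter) and a 1.3-fold higher number from compound 1 to compound 3 (0.11 log units; within the scatter) both fall within the scatter, as does a 1.2-fold lower number from compound 2 to compound 3 (0.07 log units; within the scatter), so the three cannot really be told apart.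

Compound 4 `CCS(=O)(=O)Nc1cc(-c2ccc3ncnc(Nc4ccc(C(=O)OC)c(OC)c4)c3c2)cnc1OC` has not been measured. It differs from compound 1 in one place: 3-methoxy-4-(methoxycarbonyl)phenyl in place of 3-fluorophenyl on a nitrogen on an aromatic ring. Going by the values given here, two measured steps bear on this change. Exchanging fluoro for methoxycarbonyl gave a 1.3-fold higher number from compound 1 to compound 3 (0.11 log units; within the scatter), and the move to a phenyl that also carries a methoxy gave a 1.5-fold higher number from compound 1 to compound 2 (0.18 log units; within the scatter), both within the scatter. Since neither part of the change moved the number beyond the scatter, compound 4 is expected to sit close to compound 1, with a step of roughly a 1.3-fold higher number from compound 1 to compound 4 (0.11 log units; within the scatter) in this assay. The estimate for compound 4 is therefore 2400 nM, with a range from 1000 nM to 5500 nM.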

Compound 4, half-maximal inhibitory concentration: 830 nM
Compound 4: the middle estimate sits 2.9-fold (0.46 log units) above what was measured, and the stated range ends above it.
By their numbers in this assay, from the lowest: compound 4; then compounds 1, 3 and 2 (each within the scatter of the next).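

The aryl group on this nitrogen can in fact separate compounds in this assay: 3-methoxy-4-(methoxycarbonyl)phenyl in place of 3-fluorophenyl gives a 2.2-fold lower number from compound 1 to compound 4 (0.35 log units; beyond the scatter) and lifts compound 4 out of a set that could not be told apart. The same group also gives a 2.9-fold lower number from compound 3 to compound 4 (0.46 log units; beyond the scatter) against 3-(methoxycarbonyl)phenyl and a 3.4-fold lower number from compound 2 to compound 4 (0.53 log units; beyond the scatter) against 3-chloro-4-methoxyphenyl, although all three steps remain modest. A methoxycarbonyl and a methoxy together on this phenyl, as named in compound 4, therefore did what neither the 3-(methoxycarbonyl)phenyl of compound 3 nor the 3-chloro-4-methoxyphenyl of compound 2 did.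

Compound 4 differs from compound 3 both by the added methoxy and by the place of the methoxycarbonyl in the group's name, so the compounds shown cannot separate these two changes, and they leave open whether a carboxylic acid or an amide in place of the methoxycarbonyl would keep the lower number. No measurement is available that explains the lower number of compound 4.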